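Swapping Phenyl for Pyrrolidin-2-yl in a Weak Series

The source may hold more compounds than are shown below. What is called first, only, known or untested is meant among the compounds shown, and "the series" means these compounds.

Compound 1, `c1ccc(-c2noc(-c3ccncc3)n2)cc1`, gives 710000 nM in a functional assay on LNCaP cells (Homo sapiens) for antiproliferative activity, read by MTT assay, with a stated time of 24 h; a higher number here means a weaker inhibitor, a lower number a stronger inhibitor.
Compound 2, `COc1ccc(-c2noc(-c3ccccc3)n2)cc1OC1CCCC1`, reaches only the limit > 1000000 nM in this assay.
Compound 3, `COc1ccc(-c2noc(-c3ccc(F)cc3)n2)cc1OC1CCCC1`, gives 87900 nM in this assay.

Compound 2 thus stands at the limit (the limit of > 1000000 nM in this assay, at which 1 of the 3 values shown sits), so no number is known for it, only that it is a very weak inhibitor. Compound 4, `COc1ccc(-c2noc(C3CCCN3)n2)cc1OC1CCCC1`, differs from compound 2 by pyrrolidin-2-yl in place of phenyl on an aromatic carbon. For the measured compounds named here, the only measured step, an at least 11-fold lower number from compound 2 to compound 3 (1.05 log units; beyond the scatter), concerns a different change at a different place and does not bear on this one, so no direction can be drawn from the data. Compound 4 is therefore expected to remain weak, estimated at 500000 nM, between 100000 nM and 2000000 nM. This estimate means an at least 2.0-fold lower number from compound 2 to compound 4 (0.30 log units; that floor lies within the scatter), expected but uncertain, and a limit may again be reported.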

Compound 4, half-maximal inhibitory concentration: 43 nM
The estimate for compound 4 lay 12000-fold (4.07 log units) above the measured number; measured number outside the range, below it.
By their numbers in this assay, from the lowest: compound 4; then compound 3; then compound 1. At a limit, above all of these: compound 2.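

At this carbon of the shared core, the group decides nearly everything in this assay: a non-aromatic ring carrying a nitrogen gives an at least 23000-fold lower number from compound 2 to compound 4 (4.36 log units; beyond the scatter), and it also gives a 2000-fold lower number from compound 3 to compound 4 (3.31 log units; beyond the scatter). The first of these steps is only a floor, since compound 2 stands at a limit: the limit of > 1000000 nM in this assay, at which 1 of the 4 values shown sits. The second is a full measured step, and it shows that the gain holds against the stronger of the two aryl compounds.

As far as these compounds go, whether the ring nitrogen or the non-aromatic ring carries this gain stays open. Cyclopentyl or an open-chain aminomethyl group at this carbon would separate the two.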